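The source may report more compounds than this note shows. Statements on the series, on what has been measured and on what is new or still open speak of the compounds shown alone.

Measured so far:
- compound 1 `C=CCn1c(=O)/c(=C\c2cccc(Cl)c2Cl)[nH]c(=O)/c1=C\c1ccccc1OC`: in a functional assay on U-937 cells (Homo sapiens) for cytotoxicity, read by CCK-8 assay, with a stated time of 72 h (on this read-out higher numbers stand for weaker inhibition and lower numbers for stronger inhibition), compound 1 gives 500 nM
- compound 2 `COc1ccccc1/C=c1\c(=O)[nH]/c(=C/c2cccc(Cl)c2Cl)c(=O)n1C`: in this assay compound 2 gives 100 nM

Compound 1 carries the highest of the two numbers recorded in this assay. Within the data shown here, its only neighbour is compound 2, and the step of a 5.0-fold lower number from compound 1 to compound 2 (0.70 log units; beyond the scatter) arises from hydrogen in place of vinyl on a saturated chain carbon bound to an aromatic nitrogen.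

Compound 3 `C=CCn1c(=O)/c(=C\c2ccc(C)cc2)[nH]c(=O)/c1=C\c1ccccc1OC` departs from compound 1 at a different place: 4-methylphenyl in place of 2,3-dichlorophenyl on a double-bonded chain carbon bound to an aromatic carbon. Among the measured compounds shown here, no measured pair involves this position, so the single known step, from compound 1 to compound 2, does not bear on it; it concerns the chain on the aromatic nitrogen, which compound 3 keeps unchanged from compound 1. The expectation therefore rests on compound 1 alone as the starting point, with no measured guide to direction or size.

On that footing the step of a 3.0-fold higher number from compound 1 to compound 3 (0.48 log units; beyond the scatter) is expected to be modest in this assay, but with wide uncertainty. Compound 3 is estimated at 1500 nM, within a range from 300 nM to 8000 nM.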

Compound 3, half-maximal inhibitory concentration: "not active" (no number reported)
No number was reported for compound 3; the estimate stays without a comparison.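

Among these compounds, compound 3 is reported as "not active" in this assay, without a number, so no step from compound 1 to compound 3 can be read. Nothing available bears on this result. The compounds shown leave open how far 4-methylphenyl in place of 2,3-dichlorophenyl shifts the number, and whether that change would behave alike with hydrogen on the aromatic nitrogen's chain.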